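Amide nitrogen substitution on the shared core

This account rests on a few compounds, and the source may have more. Where it says the series, first, only, none or still open, it means among the compounds named here.

Measured so far, in an assay for inhibition of 6-phosphofructo-2-kinase/fructose-2,6-bisphosphatase 3 (Homo sapiens), read by ADP-Glo, with a stated time of 2 h; on this read-out higher numbers stand for weaker inhibition and lower numbers for stronger inhibition:
- compound 1, `CN(C)C(=O)c1ccncc1Nc1cc(-c2ccc3ccn(C)c3c2)c2nccnc2c1`: 499 nM
- compound 2, `Cn1cc(NC(=O)c2ccncc2Nc2cc(-c3ccc4ccn(C)c4c3)c3nccnc3c2)cn1`: 33 nM
- compound 3, `CC(=O)N1CCCC(NC(=O)c2ccncc2Nc2cc(-c3ccc4ccn(C)c4c3)c3nccnc3c2)C1`: 11 nM

Compound 1 gives the highest number of the three in this assay; its nearest neighbour is compound 2, reached by a 15-fold lower number from compound 1 to compound 2 (1.18 log units; beyond the scatter), and the furthest is compound 3, reached by a 45-fold lower number from compound 1 to compound 3 (1.66 log units; beyond the scatter). Between those two, a 3.0-fold lower number from compound 2 to compound 3 (0.48 log units; beyond the scatter).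

Compound 4, `CN1CCC(N(C)C(=O)c2ccncc2Nc2cc(-c3ccc4ccn(C)c4c3)c3nccnc3c2)C1`, is not yet measured. Its change from compound 1 is 1-methylpyrrolidin-3-yl in place of methyl on an amide-type nitrogen.

Both measured steps from compound 1 bear on this one: each replaces the dimethylamino group on the carbonyl carbon with a larger ring-bearing group on the amide-type nitrogen, and each lowers the number by a large margin. For the measured compounds named here, compound 4 likewise carries a larger ring-bearing group there, but it keeps one methyl on that nitrogen, a pattern no measured compound shows, so the size of the effect is less certain. A step of a 4.5-fold lower number from compound 1 to compound 4 (0.66 log units; beyond the scatter) is expected, in the direction of a lower number, and compound 4 is estimated at 110 nM, within 30 nM to 400 nM.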

Compound 4, half-maximal inhibitory concentration: 176 nM
Compound 4: the middle estimate sits 1.6-fold (0.20 log units) below what was measured, and the stated range covers the measured number.
By their numbers in this assay, from the lowest: compound 3; then compound 2; then compound 4; then compound 1.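

Working notes: in this assay, a ring-bearing group on an amide-type nitrogen that keeps its methyl still helps, but only modestly, with a 2.8-fold lower number from compound 1 to compound 4 (0.45 log units; beyond the scatter) as the step. The (1-methyl-1H-pyrazol-4-yl)amino and (1-acetylpiperidin-3-yl)amino groups on the carbonyl carbon remain clearly ahead, with a 5.3-fold higher number from compound 2 to compound 4 (0.73 log units; beyond the scatter) and a 16-fold higher number from compound 3 to compound 4 (1.20 log units; beyond the scatter) as the steps, so a ring on this nitrogen does not by itself secure the large gains seen earlier. No measured evidence here accounts for these gaps.

On these data alone, since the methyl and the ring differ together in these steps, their separate shares of the gap remain open. Also open, as far as these compounds go, is how (1-methylpyrrolidin-3-yl)amino, without the methyl, or an open chain such as 2-methoxyethyl on this nitrogen would read out.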